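Swapping the Aromatic Group on the Ring Nitrogen

The source may hold more compounds than are shown below. What is called first, only, known or untested is meant among the compounds shown, and "the series" means these compounds.

Measured compounds:
compound 1, `CCCc1nc(-c2ccccc2)c(CNCCCN2CCN(c3ccc(F)cc3)CC2)o1`: 62.5%
compound 2, `CCCc1nc(-c2ccccc2)c(CNCCCN2CCN(c3cccc(F)c3)CC2)o1`: 68.9%
compound 3, `CCCc1nc(-c2ccccc2)c(CNCCCN2CCN(c3ccccc3Cl)CC2)o1`: 64.7%

Three compounds share one core and differ only in the aromatic group attached to an amine nitrogen in a ring. In an assay on HEK293 cells for inhibition of Voltage-dependent T-type calcium channel subunit alpha-1G (Homo sapiens), read by fluorescence, tested at 10 uM (a lower number here means less inhibition, a higher number more inhibition at the concentration tested (going by the name of the read-out)), compound 1 gives 62.5%, compound 2 gives 68.9% and compound 3 gives 64.7%. Compound 3 holds the second highest of the three numbers; its nearest neighbour is reached by a number 2.2 percentage points higher from compound 1 to compound 3 (within the scatter) and its furthest by a number 4.2 percentage points lower from compound 2 to compound 3 (within the scatter), so all three sit within the usual scatter of one another.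

Compound 4, `CCCc1nc(-c2ccccc2)c(CNCCCN2CCN(c3ccc(C)cc3)CC2)o1`, has not yet been measured. It differs from compound 3 in one place: 4-methylphenyl in place of 2-chlorophenyl on an amine nitrogen in a ring. The three measured steps each exchange the aromatic group on this same nitrogen, and each stays within the scatter: a number 6.4 percentage points higher from compound 1 to compound 2 (within the scatter), a number 2.2 percentage points higher from compound 1 to compound 3 (within the scatter) and a number 4.2 percentage points lower from compound 2 to compound 3 (within the scatter). Nothing in these steps points to a change beyond the scatter when a 4-methylphenyl enters, so the expected step is a number 0.3 percentage points higher from compound 3 to compound 4 (within the scatter). Compound 4 is therefore estimated to give about 65%, most likely between 50% and 78%.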

Compound 4, a percentage reported as inhibition, at one concentration (the size of the read-out at that concentration, not a potency): 53.9%
Beside the measured number, compound 4's estimate is 11.1 percentage points above it, and the stated range covers the measured number.
By their numbers in this assay, from the lowest: compounds 4, 1, 3 and 2 (each within the scatter of the next, the first and the last beyond it).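

For the compounds shown here, every earlier exchange on this ring nitrogen stayed within the scatter, whereas 4-methylphenyl gives the first steps beyond it: a number 10.8 percentage points lower from compound 3 to compound 4 (beyond the scatter) and a number 15 percentage points lower from compound 2 to compound 4 (beyond the scatter) in this assay are modest, but they show that the aromatic group at this position can move the number. Methyl in place of fluoro gives a number 8.6 percentage points lower from compound 1 to compound 4 (within the scatter) and so cannot be told from scatter, which makes compound 1 the exception to that shift.

As far as these compounds go, whether a methoxy group on the phenyl ring, or a pyridine ring in place of it, would move the number further remains open. The compounds shown offer no measurement that accounts for these steps.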